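Swapping an amide for a lactam on a sulfonamide scaffold

A few compounds are considered here, and "the series" means these few. Any claim that something is new, unique, unknown or untested is made for them only; others in the source may bear on it.

Three compounds set the scene. Compound 1 `O=C(O)c1cc(NS(=O)(=O)c2ccc(F)cc2)cnc1N1CCCCCC1` gives 41100 nM in an assay on isolated protein for inhibition of Calpain-1 catalytic subunit (Sus scrofa), read by FRET (on this read-out lower numbers stand for stronger inhibition and higher numbers for weaker inhibition), and compound 3 `O=C(O)/C(S)=C/c1ccc(I)cc1` gives 17800 nM in this assay. Compound 2 `NC(=O)c1cccc(NS(=O)(=O)c2cccc(C(F)(F)F)c2)c1`, the starting point of the step followed here, was reported as "not active" (no number reported) in this assay: no single number stands for it, so it cannot be ranked against compound 1 or compound 3, only described as a compound for which no inhibitory concentration was returned.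

Compound 4 `O=C1CCCN1c1cccc(NS(=O)(=O)c2cccc(C(F)(F)F)c2)c1` is the question. It differs from compound 2 in one place 2-oxopyrrolidin-1-yl in place of carbamoyl on an aromatic carbon, meta to a large group, so the hydrogen-bond donor of the carbamoyl is gone and a five-membered non-aromatic ring arrives. Among the measured compounds shown here, since no measured pair in this set shows what such a change does, and since compound 2 gave no number at all, the expectation for compound 4 in this assay is modest: any step is expected to stay within the scatter or, at best, to bring weak, measurable inhibition in the range seen for compound 1 and compound 3. Compound 4 is therefore estimated at 40000 nM, with a likely span from 10000 nM to 150000 nM.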

Compound 4, half-maximal inhibitory concentration: "not active" (no number reported)
Nothing numeric was reported for compound 4; the estimate stays without a comparison.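

Compound 2 and compound 4 are both reported as "not active" in this assay, with no number for either, and no step can be read between them. No measurement shown offers an explanation for this result. The compounds shown leave open whether any other group at this place would give a measurable value in this assay.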